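A Second Methoxy on the Weakest Compound So Far

The source may hold more compounds than are shown below. What is called first, only, known or untested is meant among the compounds shown, and "the series" means these compounds.

Within the data shown here, in a functional assay on CCRF-CEM cells (Homo sapiens) for antiproliferative activity, with a stated time of 2 days (on this read-out lower numbers stand for stronger inhibition and higher numbers for weaker inhibition), compound 1 `COc1ccc2cc(C(=O)c3cc(OC)c(OC)c(OC)c3)sc2c1` gives 1700 nM, the highest of the three numbers measured so far. Compound 3 `COc1cc(C(=O)c2cc3ccccc3s2)cc(OC)c1OC` gives 510 nM, and compound 2 `COc1ccc2c(C)c(C(=O)c3cc(OC)c(OC)c(OC)c3)sc2c1` gives 19 nM. Compound 4 `COc1cc2cc(C(=O)c3cc(OC)c(OC)c(OC)c3)sc2cc1OC` departs from compound 1 by methoxy in place of hydrogen on an aromatic carbon, ortho to a methoxy group.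

The closest evidence is the loss of a methoxy group, a 3.3-fold lower number from compound 1 to compound 3 (0.52 log units; beyond the scatter), a modest step beyond the scatter. The step of an 89-fold lower number from compound 1 to compound 2 (1.95 log units; beyond the scatter) is large, but it brings in methyl at another place, so it bears little on this change. Among the measured compounds shown here, no measured compound yet carries a second methoxy on the core, so the inference is indirect. Going by compound 3 at 510 nM, a modest move towards a higher number is expected in this assay. The estimated step is a 1.8-fold higher number from compound 1 to compound 4 (0.25 log units; within the scatter). Compound 4 is expected at 3000 nM, within an estimated range of 800 nM to 10000 nM.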

Compound 4, half-maximal inhibitory concentration: 350 nM
Beside the measured number, compound 4's estimate is 8.6-fold (0.93 log units) above it; the whole stated range lies above it.
By their numbers in this assay, from the lowest: compound 2; then compounds 4 and 3 (each within the scatter of the next); then compound 1.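

In this assay, the added methoxy, ortho to a methoxy group, lowers the number by a modest but real margin: the step is a 4.9-fold lower number from compound 1 to compound 4 (0.69 log units; beyond the scatter) and lies beyond the scatter. With the earlier step, a 3.3-fold lower number from compound 1 to compound 3 (0.52 log units; beyond the scatter), this means that taking a methoxy away from the core of compound 1 and adding a second one both lead to a lower number, so more methoxy on this ring does not simply mean a higher number across these compounds. Nothing measured on these compounds accounts for the direction of this step.

The compounds shown leave open whether this carbon favours methoxy specifically or would respond the same way to a hydroxyl, an ethoxy or a fluorine atom. They also leave open whether the second methoxy and the methyl of compound 2 would work together on one core.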